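The compounds below may be only part of what the source reports. "The series", "measured", "known", "first", "only" and "open" are said of these compounds alone.

In a functional assay on BGC-823 cells (Homo sapiens) for inhibition, read by MTT assay, with a stated time of 72 h (a lower number here means a stronger inhibitor, a higher number a weaker inhibitor), compound 1 `COc1cc2c(Nc3cccc([N+](=O)[O-])c3)ncnc2c(OC)c1OC` gives 39000 nM and compound 2 `COc1cc2c(Nc3ccc([N+](=O)[O-])cc3)ncnc2c(OC)c1OC` gives 32200 nM, while compound 3 `COc1cc2c(Nc3ccc(O)cc3)ncnc2c(OC)c1OC` gives 35400 nM and so sits level with both, all three within the usual scatter of one another. Compound 4 `COc1cc2c(Nc3ccc(Cl)cc3)ncnc2c(OC)c1OC` differs from compound 3 by a single swap chloro in place of hydroxy on an aromatic carbon with chloro in place of hydroxy on an aromatic carbon, para to a large group. Among the measured compounds shown here, the one measured step at that place, hydroxy in place of nitro, is a 1.1-fold higher number from compound 2 to compound 3 (0.04 log units; within the scatter) and stays within the scatter. For the measured compounds named here, no measured compound carries chloro, so this guide is thin. The step expected in this assay is a 1.3-fold lower number from compound 3 to compound 4 (0.10 log units; within the scatter) and thus none beyond the scatter. For compound 4 the estimated value is 28000 nM with an expected range from 11000 nM to 60000 nM once it is measured.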

Compound 4, half-maximal inhibitory concentration: 34400 nM
The estimate for compound 4 lay 1.2-fold (0.09 log units) below the measured number; the range from low to high includes it.
By their numbers in this assay, from the lowest: compounds 2, 4, 3 and 1 (each within the scatter of the next).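

In this assay, chloro on this carbon, para to a large group, gives a 1.0-fold lower number from compound 3 to compound 4 (0.01 log units; within the scatter) and a 1.1-fold higher number from compound 2 to compound 4 (0.03 log units; within the scatter). Hydroxy, nitro and chloro thus all read level here, so losing the hydrogen-bond donor and acceptor that hydroxy carries, as in (4-chlorophenyl)amino, brings no change beyond the scatter. Nothing measured here explains why these numbers stay level.

None of the compounds shown has an amine, a carboxylic acid or a longer chain at this place. From the compounds shown here alone, whether any such group would move the number beyond the scatter remains open.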